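Bromo for fluoro on the sulfonamide aryl of compound 1

This account rests on a few compounds, and the source may have more. Where it says the series, first, only, none or still open, it means among the compounds named here.

Three compounds share one core. Compound 1 `COc1ccc(F)cc1S(=O)(=O)Nc1cncc(C(N)=O)c1` gives 19 nM in an assay on isolated protein for inhibition of alkaline phosphatase, tissue-nonspecific isozyme (Homo sapiens); on this read-out higher numbers stand for weaker inhibition and lower numbers for stronger inhibition. Compound 2 `COc1ccc(Cl)cc1S(=O)(=O)Nc1cncc(-c2ccncc2)c1` gives 73 nM, and compound 3 `COc1ccc(Cl)cc1S(=O)(=O)Nc1cncc(-c2ccc(C)cc2)c1` gives 147 nM. Compound 1 stands lowest of the three, with compound 2 nearest and compound 3 furthest, both separated from it beyond the scatter.

For the measured compounds named here, the only step between measured compounds, a 2.0-fold higher number from compound 2 to compound 3 (0.30 log units; within the scatter), exchanges one aromatic substituent for another at a different place and stays within the scatter; it does not touch the group that changes here.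

Compound 4 `COc1ccc(Br)cc1S(=O)(=O)Nc1cncc(C(N)=O)c1` differs from compound 1 in one place: bromo in place of fluoro on an aromatic carbon. Going by the values given here, no measured pair varies this group, so the change is untested within this set, and the one measured step gives no reason to expect a large move. He therefore expects compound 4 to stay close to compound 1, with a step of a 1.1-fold higher number from compound 1 to compound 4 (0.02 log units; within the scatter) in this assay, not beyond the scatter. His estimate for compound 4 is 20 nM, ranging from 8 nM to 50 nM.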

Compound 4, half-maximal inhibitory concentration: 14 nM
Compound 4: middle estimate off by 1.4-fold (0.15 log units), on the high side, and the stated range covers the measured number.
By their numbers in this assay, from the lowest: compounds 4 and 1 (each within the scatter of the next); then compounds 2 and 3 (each within the scatter of the next).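

Bromo in place of fluoro, on the aromatic carbon para to a methoxy group and meta to a large group, gives (a 1.4-fold lower number from compound 1 to compound 4 (0.13 log units; within the scatter)) in this assay. For the compounds shown here, this is the first measured change at this position, and it shows that fluoro and bromo are not told apart here, so two compounds rather than one now stand at the low end of the set. No measurement on hand gives a reason for this result.

The compounds shown leave open whether this carbon would hold its number with an amine or a carboxylic acid in place of the halogen. They also leave open whether bromo and fluoro would stay within the scatter of each other with pyridin-4-yl or 4-methylphenyl in place of the carboxamide.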